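Removing a Carboxymethyl Group From Compound 2

The source may report more compounds than this note shows. Statements on the series, on what has been measured and on what is new or still open speak of the compounds shown alone.

The measured compounds and their readings:
Compound 1, `O=C(CN(c1ncnc2c1ncn2C1CCCCO1)C1CC1)NCC(=O)OCc1ccccc1`, gives 25.9% in a functional assay on the whole organism (Tail, strain ICR) with Mus musculus as the target, in the tail flick test, with a stated time of 90 min, at a dose of 25 umol/kg by the oral route; on this read-out lower numbers stand for a weaker effect and higher numbers for a stronger effect at the one dose given.
Compound 2, `O=C(O)C[C@H](NC(=O)CN(c1nc(Cl)nc2[nH]cnc12)C1CC1)C(=O)O`, gives 25.1% in this assay.
Compound 3, `O=C(OCc1ccccc1)[C@@H]1CCCN1C(=O)CN(c1ncnc2c1ncn2C1CCCCO1)C1CC1`, gives 23.3% in this assay.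

Compound 2 stands second highest of the three numbers. Its nearest neighbour is compound 1, whose number is a fraction higher, and the furthest is compound 3, whose number is a little lower; both gaps lie within the scatter, so the three readings cannot be told apart. No pair of these compounds differs in only one place, so no step between measured compounds is available.

The unmeasured compound 4, `O=C(O)CNC(=O)CN(c1nc(Cl)nc2[nH]cnc12)C1CC1`, differs from compound 2 by a single change: hydrogen in place of carboxymethyl on a saturated chain carbon bound to an amide-type nitrogen and a carbonyl carbon. Among the measured compounds shown here, nothing among the measured compounds shows what such a change does in this assay, since the three readings sit within the scatter of one another despite quite different groups on the amide side of the shared core. On that basis, compound 4 is expected to show no step beyond the scatter, in either direction, in this assay. The estimate for compound 4 is 25%, with a range from 12% to 38%, which corresponds to an expected step of a number 0.1 percentage points lower from compound 2 to compound 4 (within the scatter).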

Compound 4, a percentage reported as activity, at one dose (the size of the read-out at that dose, not a potency): 32.3%
Estimate against measurement, compound 4: 7.3 percentage points below; measured number inside the range.
By their numbers in this assay, from the lowest: compounds 3, 2, 1 and 4 (each within the scatter of the next).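

In this assay, among the compounds shown here, hydrogen in place of carboxymethyl on a saturated chain carbon bound to an amide-type nitrogen and a carbonyl carbon gives a number 7.2 percentage points higher from compound 2 to compound 4 (within the scatter), the first reading of a change made at this one place. The carboxymethyl group that leaves holds 4 heavy atoms, including 1 hydrogen-bond donor and 1 hydrogen-bond acceptor, yet at the single dose given this read-out does not separate the compounds with and without it, so the group is not shown to matter here. Nothing measured on these compounds offers an explanation for this result.

The compounds shown leave open whether a longer chain such as carboxyethyl, a methyl group or an amine such as aminomethyl on this carbon would give a reading beyond the scatter from compound 2. They also leave open whether the same replacement would read alike on the core of compound 1, and whether compound 2 and compound 4 would stay inseparable at other doses, as one dose gives the size of an effect and not a potency.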